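From 3-methylphenyl to 4-methylphenyl in compound 4

A few compounds are considered here, and "the series" means these few. Any claim that something is new, unique, unknown or untested is made for them only; others in the source may bear on it.

Results so far in a physicochemical assay for permeability, using PAMPA (a higher number here means that the compound crosses the layer faster, a lower number that the compound crosses the layer more slowly), are these:
Compound 1 `Cc1cc(C)c(-c2nc(CN3CCC(C(=O)NCCCN4C[C@H](C)C[C@H](C)C4)CC3)c(C)o2)c(C)c1` gives "not determined" (no result reported)
Compound 2 `Cc1cccc(F)c1-c1nc(CN2CCC(C(=O)NCCCN3C[C@H](C)C[C@H](C)C3)CC2)c(C)o1` gives 234 10^-6 cm/s
Compound 3 `Cc1cccc(-c2nc(CN3CCC(C(=O)NCCCN4C[C@H](C)C[C@H](C)C4)CC3)c(C)o2)c1` gives 279 10^-6 cm/s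

Compound 2 at 234 10^-6 cm/s and compound 3 at 279 10^-6 cm/s lie within the scatter of each other, so neither can be ranked above the other. Within the data shown here, compound 1 offers no number for comparison, which leaves compound 3 level with the only other measured compound.

Compound 4 `Cc1ccc(-c2nc(CN3CCC(C(=O)NCCCN4C[C@H](C)C[C@H](C)C4)CC3)c(C)o2)cc1` has yet to be measured. It has the same atoms as compound 3, joined differently, with 4-methylphenyl in place of 3-methylphenyl on an aromatic carbon (the rest of the structure is shared).

Among the measured compounds shown here, only one measured step bears on this change. It puts 3-methylphenyl in place of 2-fluoro-6-methylphenyl on that same aromatic carbon, and a 1.2-fold higher number from compound 2 to compound 3 (0.08 log units; within the scatter) lies within the scatter. One step is a thin basis, but it gives no reason to expect a change beyond the scatter in this assay here, and no direction can be drawn from it.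

The expected result is a 1.1-fold lower number from compound 3 to compound 4 (0.02 log units; within the scatter) and stays within the scatter. The estimate for compound 4 is 265 10^-6 cm/s (expected range 155 10^-6 cm/s to 450 10^-6 cm/s).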

Compound 4, apparent permeability: 274 10^-6 cm/s
For compound 4 the middle estimate is 1.0-fold (0.01 log units) below the measured one; the measured number falls inside the stated range.
By their numbers in this assay, from the lowest: compounds 2, 4 and 3 (each within the scatter of the next).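

In this assay, 4-methylphenyl in place of 3-methylphenyl, on the aromatic carbon next to the ring nitrogen and next to the ring oxygen, gives a 1.0-fold lower number from compound 3 to compound 4 (0.01 log units; within the scatter), so this exchange between two groups with the same atoms stays within the scatter. Replacing 2-fluoro-6-methylphenyl with 4-methylphenyl at that same carbon gives a 1.2-fold higher number from compound 2 to compound 4 (0.07 log units; within the scatter), which also stays within the scatter, and the three measured groups at this position, now including both methylphenyl isomers, cannot be ranked in this assay. Nothing available on these compounds offers an explanation for why the numbers at this position lie so close together.

All the groups shown at this carbon are phenyl rings that carry a methyl group, so the compounds leave open whether a phenyl ring bearing an amine or a carboxylic acid, or a pyridine ring in place of the phenyl, would also stay within the scatter. They also leave open whether a longer chain in the part of the structure that these compounds share would give a number beyond the scatter.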